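A few compounds are considered here, and "the series" means these few. Any claim that something is new, unique, unknown or untested is made for them only; others in the source may bear on it.

Three compounds share one core and were measured in a functional assay on the whole organism for inhibition, with Mus musculus as the target, with a stated time of 1 h, at a dose of 30 mg/kg by the intraperitoneal route; a lower number here means less inhibition, a higher number more inhibition at the dose given (going by the name of the read-out):

Compound 1 `O=C(/C=C/C1=Cc2ccccc2OC1)c1ccccc1F`: 64.4%
Compound 2 `O=C(/C=C/C1=Cc2ccccc2OC1)c1ccc(F)cc1`: 65.6%
Compound 3 `O=C(/C=C/C1=Cc2ccccc2OC1)c1ccc([N+](=O)[O-])cc1`: 50.8%

Compound 3 stands lowest of the three. Its nearest neighbour is compound 1, whose value lies higher by a margin beyond the scatter, and compound 2 lies further above it, also beyond the scatter. Between compound 1 and compound 2 the change a number 1.2 percentage points higher from compound 1 to compound 2 (within the scatter) lies within the scatter, so the two fluoro compounds cannot be ordered. Between compound 2 and compound 3 the change a number 14.8 percentage points lower from compound 2 to compound 3 (beyond the scatter) is a modest drop beyond the scatter.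

Compound 4 `Cc1ccc(C(=O)/C=C/C2=Cc3ccccc3OC2)cc1` has not been measured. It differs from compound 3 in one place: methyl in place of nitro on an aromatic carbon. Going by the values given here, the only measured step that bears on this position is the one from compound 2 to compound 3, where nitro entered in place of fluoro and the value fell by a number 14.8 percentage points lower from compound 2 to compound 3 (beyond the scatter). Among the compounds with values here, removing the nitro again, now for a methyl, is expected to undo that loss and to bring compound 4 back near the level of compound 1 and compound 2, with uncertainty because no methyl analogue has been measured.

Compound 4 is therefore estimated at 62%, in the range 48% to 76%, which means an expected step of a number 11.2 percentage points higher from compound 3 to compound 4 (beyond the scatter).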

Compound 4, a percentage reported as inhibition, in the whole organism at one dose (the size of the read-out at that dose, not a potency): 53.1%
Beside the measured number, compound 4's estimate is 8.9 percentage points above it; measured number inside the range.
By their numbers in this assay, from the lowest: compounds 3 and 4 (each within the scatter of the next); then compounds 1 and 2 (each within the scatter of the next).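

In this assay, replacing nitro with methyl gives a number 2.3 percentage points higher from compound 3 to compound 4 (within the scatter), so removing the nitro does not by itself recover the level of the fluoro compounds. Against the fluoro compounds, methyl in place of fluoro on the same aromatic carbon gives a number 12.5 percentage points lower from compound 2 to compound 4 (beyond the scatter), and 4-methylphenyl in place of 2-fluorophenyl on the carbonyl carbon gives a number 11.3 percentage points lower from compound 1 to compound 4 (beyond the scatter), so the methyl compound falls short of both. The lower level seen with nitro is therefore not peculiar to that group: methyl, with one heavy atom and no hydrogen-bond acceptors, cannot be told apart from nitro, with three heavy atoms and two hydrogen-bond acceptors, and only fluoro stands higher among the three groups at this position.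

No accompanying measurement explains why the fluoro compounds stand apart from the other two. The compounds shown leave open whether the higher level belongs to fluoro alone or would also appear with chloro, methoxy or an amine on this aromatic carbon, or with the parent phenyl carrying no added group.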